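The source may hold more compounds than are shown below. What is called first, only, known or untested is meant among the compounds shown, and "the series" means these compounds.

Compound 1 `N#CC1=C(N)N(c2ccc(S(N)(=O)=O)cc2)C2=C(CCCC2)C1c1ccc([N+](=O)[O-])cc1`: 10%
Compound 2 `N#CC1=C(N)N(c2ccc(S(N)(=O)=O)cc2)C2=C(CCCC2)C1c1c(O)ccc2ccccc12`: 20%

In a functional assay on Ehrlich cells (Mus musculus) for cytotoxicity, read by trypan blue exclusion, with a stated time of 2 h, tested at 50 ug/mL (on this read-out higher numbers stand for a stronger effect at the one concentration tested and lower numbers for a weaker effect), compound 2 gives 20%, and compound 1 gives 10%; the step of a number 10 percentage points higher from compound 1 to compound 2 (within the scatter) lies within the scatter, so the two numbers cannot be ranked. Compound 3 `Cc1ccc(C2C(C#N)=C(N)N(c3ccc(S(N)(=O)=O)cc3)C3=C2CCCC3)o1` differs from compound 2 by 5-methylfuran-2-yl in place of 2-hydroxynaphthalen-1-yl on a saturated ring carbon. Going by the values given here, the one measured step, a number 10 percentage points higher from compound 1 to compound 2 (within the scatter), also exchanged the group on that saturated ring carbon and stayed within the scatter, so no step beyond the scatter is expected in this assay here either. Compound 3 is estimated at 13%, between 3% and 28%, an expected step of a number 7 percentage points lower from compound 2 to compound 3 (within the scatter).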

Compound 3, a percentage reported as activity, at one concentration (the size of the read-out at that concentration, not a potency): 10%
Estimate against measurement, compound 3: 3 percentage points above; low and high end bracket the measured number.
By their numbers in this assay, from the lowest: compounds 1, 3 and 2 (each within the scatter of the next).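

In this assay, 5-methylfuran-2-yl on the saturated ring carbon gives a number 10 percentage points lower from compound 2 to compound 3 (within the scatter) and no change at the digits printed from compound 1 to compound 3 (within the scatter). A five-membered aromatic ring with 1 hetero atom therefore joins the two earlier groups at this position, and the three compounds cannot be ranked, even though the hydrogen-bond donor of 2-hydroxynaphthalen-1-yl is gone in compound 3. Nothing available offers an explanation for this result. On these data alone, whether an amine or a carboxylic acid on this carbon would give a step beyond the scatter remains open. So does whether any of these groups would separate at another concentration.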